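The compounds below may be only part of what the source reports. "The series", "measured", "known", "first", "only" and "open" are said of these compounds alone.

Measured so far:
Compound 1, `Cc1nc2c(OCc3ccccc3)cccn2c1CO` — in a functional assay on the whole organism (stomach) for inhibition, with Canis familiaris (Canis lupus familiaris) as the target, at a dose of 5 mg/kg by the intravenous route; on this read-out higher numbers stand for a stronger effect at the one dose given and lower numbers for a weaker effect: 80%
Compound 2, `CCSCc1c(C)nc2c(OCc3ccccc3)cccn12` — in this assay: 0%

Compound 2 stands lowest of the two numbers in this assay; its nearest neighbour is compound 1, which is higher by a step beyond the scatter. The change that leads on from compound 2 to compound 3, `Cc1nc2c(OCc3ccccc3)cccn2c1CS(C)(=O)=O`, is methylsulfonyl in place of ethylsulfanyl on a saturated chain carbon bound to an aromatic carbon. Among the measured compounds shown here, only one measured step touches the same position, and it went the other way in kind: a number 80 percentage points lower from compound 1 to compound 2 (beyond the scatter), from the hydroxy group to the ethylsulfanyl group. Methylsulfonyl is neither of those two groups, so the one step gives only a loose guide. Compound 3 is expected to recover part, but not all, of the lost inhibition, an estimated a number 30 percentage points higher from compound 2 to compound 3 (beyond the scatter). Compound 3 is therefore estimated at 30% in this assay, with a range from 0% to 70%.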

Compound 3, a percentage reported as inhibition, in the whole organism at one dose (the size of the read-out at that dose, not a potency): 0%
Compound 3: middle estimate off by 30 percentage points, on the high side, and the stated range covers the measured number.
By their numbers in this assay, from the lowest: compounds 2 and 3 (each within the scatter of the next); then compound 1.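

In this assay, methylsulfonyl in place of ethylsulfanyl on a saturated chain carbon bound to an aromatic carbon gives no change at the digits printed from compound 2 to compound 3 (within the scatter), so the second sulfur group does not restore the inhibition. Methylsulfonyl in place of hydroxy gives a number 80 percentage points lower from compound 1 to compound 3 (beyond the scatter), which shows that the loss first seen with ethylsulfanyl is not confined to that one group, and of the three compounds only compound 1, with its hydroxy group, keeps the effect at this dose. Nothing measured here explains this difference between the hydroxy compound and the two sulfur compounds.

As far as these compounds go, it remains open whether a methoxy group, an amine or a carboxylic acid at this place would keep the inhibition. Whether compound 2 and compound 3 would differ at another dose also stays unanswered.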